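The source may report more compounds than this note shows. Statements on the series, on what has been measured and on what is new or still open speak of the compounds shown alone.

Of the compounds shown here, three sharing one core have been measured in a functional assay on K562 cells (Homo sapiens) for cytotoxicity, read by MTT assay, with a stated time of 3 days; a lower number here means a stronger inhibitor, a higher number a weaker inhibitor. Compound 1 `N#Cc1c(Nc2ccccn2)nc(SCc2nc3ccccc3[nH]2)nc1-c1ccccc1` gives 7 nM, compound 2 `N#Cc1c(NNC(N)=S)nc(SCc2nc3ccccc3[nH]2)nc1-c1ccccc1` gives 8.9 nM, and compound 3 `N#Cc1c(-c2ccccc2)nc(SCc2nc3ccccc3[nH]2)nc1N1CCNCC1` gives 4.38 nM. Compound 3 therefore sits at the low end of these numbers together with compound 1, as the data show a 1.6-fold lower number from compound 1 to compound 3 (0.20 log units; within the scatter). Its distance from the third compound is only slightly larger, at a 2.0-fold lower number from compound 2 to compound 3 (0.31 log units; beyond the scatter).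

Compound 4 `N#Cc1c(-c2ccccc2)nc(SCc2nc3ccccc3[nH]2)nc1N1CCN(S(=O)(=O)c2ccccc2)CC1` keeps all of compound 3 except for one change, which is phenylsulfonyl in place of hydrogen on an amine nitrogen in a ring. In words, this is phenylsulfonyl in place of hydrogen on an amine nitrogen in a ring.

Among the measured compounds shown here, no measured compound carries a group on that nitrogen, so the evidence is indirect. The closest guide comes from the swaps of the whole group on the aromatic carbon, which have stayed small. Besides the two steps above, the data show a 1.3-fold higher number from compound 1 to compound 2 (0.10 log units; within the scatter). A small change is thus the best guess in this assay, with a slight lean towards a higher number, although the new group is large and untested here. For compound 4 the expected step is a 1.4-fold higher number from compound 3 to compound 4 (0.14 log units; within the scatter), which is no step beyond the scatter. Compound 4 is estimated at 6 nM. The estimated range for compound 4 runs from 2 nM to 25 nM.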

Compound 4, half-maximal inhibitory concentration: 3 nM
Compound 4: middle estimate off by 2.0-fold (0.30 log units), on the high side, within the range that was stated.
By their numbers in this assay, from the lowest: compounds 4, 3, 1 and 2 (each within the scatter of the next, the first and the last beyond it).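

In this assay placing phenylsulfonyl on the amine nitrogen in the ring gives a 1.5-fold lower number from compound 3 to compound 4 (0.16 log units; within the scatter) and so no change that stands out of the scatter. The earlier compounds shown here differ only in the whole group on the aromatic carbon, so they could not show that the hydrogen on this nitrogen can be replaced without losing the low number. Compound 4 now shows that a group with an aromatic ring of carbon only and 2 hydrogen-bond acceptors is accepted at this position, at least for this one group. Nothing measured in the data shown accounts for this result, so no cause can be given for it.

Going by these compounds, it remains open whether much smaller groups on that nitrogen, such as methyl or acetyl, or a longer chain ending in a carboxylic acid, would keep the number as low. Also open, on these data alone, is whether methylsulfonyl, which lacks the phenyl ring, or a benzoyl group, which replaces the sulfonyl with a carbonyl, would behave like phenylsulfonyl.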